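This account rests on a few compounds, and the source may have more. Where it says the series, first, only, none or still open, it means among the compounds named here.

Measured so far:
Compound 1 `O=C(COc1cccc2ccccc12)N/N=C/c1cccc([N+](=O)[O-])c1` gives 12.1 ug/mL.
Compound 2 `Cc1ccc(/C=N/NC(=O)COc2cccc3ccccc23)cc1` gives 83.9 ug/mL.
Compound 3 `O=C(COc1cccc2ccccc12)N/N=C/c1ccc([N+](=O)[O-])cc1` gives 87.9 ug/mL.

All three numbers come from an ADME assay on MT4 cells (Homo sapiens) for cytotoxicity, read by MTT assay, with a stated time of 4 days; a higher number here means that more compound is tolerated, a lower number that less compound is tolerated. Compound 3 stands at the highest of the three numbers, meaning the cells tolerated the most of it. Its nearest companion is compound 2, and the step between them, a 1.0-fold higher number from compound 2 to compound 3 (0.02 log units; within the scatter), is too small to count as a real difference. Compound 1 sits far lower, by a gap that does lie beyond the scatter.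

The next compound, compound 4 `O=C(COc1cccc2ccccc12)N/N=C/c1ccccc1`, is not yet measured. It differs from compound 3 in a single place: hydrogen in place of nitro on an aromatic carbon. For the measured compounds named here, the only measured step that bears on this is a 1.0-fold higher number from compound 2 to compound 3 (0.02 log units; within the scatter), which swaps one group for another at that aromatic carbon and leaves the number essentially unchanged. Going by the values given here, no measured step replaces a group there with hydrogen, so the move to compound 4 has no direct precedent. Because a 1.0-fold higher number from compound 2 to compound 3 (0.02 log units; within the scatter) shows two quite different groups giving the same outcome in this assay, the expectation is that hydrogen there will also change little, and the estimated step of a 1.5-fold lower number from compound 3 to compound 4 (0.17 log units; within the scatter) is expected to fall within the scatter or only slightly below it. Compound 4 is therefore estimated at 60 ug/mL, with a range from 20 ug/mL to 150 ug/mL.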

Compound 4, half-maximal cytotoxic concentration: >= 96.6 ug/mL
Compound 4: no number, only a limit; the forecaster's own chance of this, stated with the estimate: 10%; at least 1.6-fold (0.20 log units) between middle value and limit.
By their numbers in this assay, from the lowest: compound 1; then compounds 2 and 3 (each within the scatter of the next). At a limit, above all of these: compound 4.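

In this assay compound 4, with bare hydrogen on the ring where the others carry a group, gives only a limit of the assay and not a number: the limit of >= 96.6 ug/mL in this assay, at which 1 of the 4 values shown sits.

At the place para to a large group, replacing the group with hydrogen gives an at least 1.0-fold higher number from compound 3 to compound 4 (0.04 log units; that floor lies within the scatter) for the loss of nitro and an at least 1.1-fold higher number from compound 2 to compound 4 (0.06 log units; that floor lies within the scatter) for the loss of methyl, so neither group is needed for the cells to tolerate this much compound, though the true size of these two steps cannot be read from a floor. The same swap of nitro for hydrogen gives a clear gap in an at least 7.9-fold higher number from compound 1 to compound 4 (0.90 log units; beyond the scatter), which shows that removing a nitro has a plain effect on the number only when starting from the low-reading compound, so where the nitro stands matters more here than whether a ring group is present at all.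

On these data alone, how far the true number of compound 4 lies past its limit stays open, and with it whether nitro or methyl at the place para to a large group lowers the tolerated amount at all. As far as these compounds go, how an amine, a carboxylic acid or a methoxy group at that place would read in this assay also stays open.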